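This account rests on a few compounds, and the source may have more. Where it says the series, first, only, none or still open, it means among the compounds named here.

Of the compounds shown here, three built on one shared core have been measured in a functional assay on the whole organism (strain albino) for inhibition, with Rattus norvegicus as the target, read by paw edema, with stated times of 1 h and 3 h, at a dose of 20 mmol/kg by the intraperitoneal route; a higher number here means a stronger effect of the compound at the dose given, a lower number a weaker effect. Compound 1 `N#CC1=C(NCN2CCCC2)N(c2ccccc2)C(=O)N2CCCCC(N3CCCC3)C12` gives 35.3% in this assay. Compound 2 `N#CC1=C(NCC(=O)N2CCCC2)N(c2ccccc2)C(=O)N2CCCCC(N3CCCC3)C12` gives 56%, and between the two lies a number 20.7 percentage points higher from compound 1 to compound 2 (beyond the scatter). Compound 3 `N#CC1=C(/N=C/c2ccccc2)N(c2ccccc2)C(=O)N2CCCCC(N3CCCC3)C12` gives 84%, the highest of the three numbers: a number 28 percentage points higher from compound 2 to compound 3 (beyond the scatter), and a number 48.7 percentage points higher from compound 1 to compound 3 (beyond the scatter). Both steps toward compound 3 exchange the whole group on the double-bonded ring carbon, and in both the group that enters carries the six-membered aromatic ring of carbon only.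

Compound 4 `N#CC1=C(/N=C/c2ccc([N+](=O)[O-])cc2)N(c2ccccc2)C(=O)N2CCCCC(N3CCCC3)C12` keeps that ring and differs from compound 3 only there: nitro in place of hydrogen on an aromatic carbon. Among the measured compounds shown here, none of the three measured steps touches an aromatic carbon of that ring; each replaces the entire group on the double-bonded ring carbon, so no measured step bears directly on this change. For the measured compounds named here, what the data show is only that the ring itself is kept in the strongest member, compound 3, which gives 84%. Going by the values given here, with no comparable step to lean on, the expected step is a number 4 percentage points lower from compound 3 to compound 4 (within the scatter), that is, nothing beyond the scatter in either direction. Compound 4 is therefore estimated at 80%, within a range from 60% to 95% in this assay.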

Compound 4, a percentage reported as inhibition, in the whole organism at one dose (the size of the read-out at that dose, not a potency): 91.7%
Compound 4: the middle estimate sits 11.7 percentage points below what was measured, and the stated range covers the measured number.
By their numbers in this assay, from the lowest: compound 1; then compound 2; then compounds 3 and 4 (each within the scatter of the next).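

Among the compounds shown here, the nitro group gives the first reading on a substituted aromatic carbon of this ring, para to a large group, and in this assay the change from phenyl to 4-nitrophenyl comes to a number 7.7 percentage points higher from compound 3 to compound 4 (within the scatter) on the scale of this test, so the two compounds cannot be told apart. The high numbers seen with the unsubstituted ring therefore persist with nitro in place of hydrogen: exchanging the whole group on the double-bonded ring carbon gives a number 35.7 percentage points higher from compound 2 to compound 4 (beyond the scatter) and, against the lowest member of the set, a number 56.4 percentage points higher from compound 1 to compound 4 (beyond the scatter) in the same direction as the steps to compound 3. Nothing measured alongside these numbers offers an explanation of why the nitro group makes so little difference.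

With hydrogen and nitro the only two groups shown at this place, it stays open whether an amine, a carboxylic acid or a methoxy group on the same aromatic carbon would also stay within the scatter of compound 3. Going by these compounds, it also stays open how nitro would read on another carbon of the ring, and whether a longer chain between the ring and the double-bonded ring carbon would keep these numbers.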